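Triazole-linked terpenoid esters: aryl change on the triazole nitrogen

The source may report more compounds than this note shows. Statements on the series, on what has been measured and on what is new or still open speak of the compounds shown alone.

Measured so far in a functional assay on A549 cells (Homo sapiens) for antiproliferative activity, read by MTT assay, with a stated time of 48 h; a lower number here means a stronger inhibitor, a higher number a weaker inhibitor:
compound 1 `C/C(=C\CC/C(C)=C/CC[C@@H]1[C@@]2(C)CCC(=O)C(C)(C)[C@H]2CC[C@@]1(C)O)CC/C=C(\C)C(=O)OCc1cn(-c2cccc(O)c2)nn1` gives 42800 nM
compound 2 `C/C(=C\CC/C(C)=C/CC[C@@H]1[C@@]2(C)CCC(=O)C(C)(C)[C@H]2CC[C@@]1(C)O)CC/C=C(\C)C(=O)OCc1cn(-c2ccccc2)nn1` gives only a limit, > 150000 nM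
compound 3 `C/C(=C\CC/C(C)=C/CC[C@@H]1[C@@]2(C)CCC(=O)C(C)(C)[C@H]2CC[C@@]1(C)O)CC/C=C(\C)C(=O)OCc1cn(-c2ccc(C)cc2)nn1` gives only a limit, > 150000 nM

Compound 3 stands at the limit of this assay, a position it shares with one other value (the limit of > 150000 nM in this assay, at which 2 of the 3 values shown sit). The step to compound 4 `C/C(=C\CC/C(C)=C/CC[C@@H]1[C@@]2(C)CCC(=O)C(C)(C)[C@H]2CC[C@@]1(C)O)CC/C=C(\C)C(=O)OCc1cn(-c2cccc(Br)c2)nn1` is 3-bromophenyl in place of 4-methylphenyl on an aromatic nitrogen. Among the compounds with values here, the steps that bear on it are an at least 3.5-fold higher number from compound 1 to compound 2 (0.54 log units; beyond the scatter) and an at least 3.5-fold higher number from compound 1 to compound 3 (0.54 log units; beyond the scatter); the step that the two limits leave unreadable from compound 2 to compound 3. Both readable steps point to weaker inhibition once the 3-hydroxyphenyl is replaced, and compound 4 also lacks that hydroxy. Compound 4 is therefore expected to remain weak, with a step of an at least 1.2-fold lower number from compound 3 to compound 4 (0.09 log units; that floor lies within the scatter), and its estimated value in this assay is 120000 nM (range 40000 nM to 300000 nM).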

Compound 4, half-maximal inhibitory concentration: > 150000 nM
Compound 4: a limit, no number; the forecaster's own chance of this, stated with the estimate: 55%; middle value at least 1.2-fold (0.09 log units) away from the limit.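

In this assay compound 4 gives only a limit, > 150000 nM. The change of hydroxy to bromo on the aromatic carbon gives an at least 3.5-fold higher number from compound 1 to compound 4 (0.54 log units; beyond the scatter), so the 3-hydroxyphenyl remains the only aryl group shown that gives a number. The steps among compound 2, compound 3 and compound 4 cannot be read, and the limit now holds most of the series: the limit of > 150000 nM in this assay, at which 3 of the 4 values shown sit.

On these data alone, whether an amine or a methoxy in place of that hydroxy would also give a number stays open. So does how far any aryl group without the hydroxy lies past the limit.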